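A few compounds are considered here, and "the series" means these few. Any claim that something is new, unique, unknown or untested is made for them only; others in the source may bear on it.

Values in a functional assay on the whole organism with Rattus norvegicus as the target; on this read-out higher numbers stand for an effect only at larger amounts of compound and lower numbers for an effect already at smaller amounts:
- Compound 1 `CCN(CCNC(=O)c1cc(Cl)c(N)cc1OC)Cc1ccccc1`: 0.31 mg/kg
- Compound 2 `CCNCCNC(=O)c1cc(Cl)c(N)cc1OC`: > 30 mg/kg (a limit, not a number)
- Compound 3 `CCN(CCNC(=O)c1cc(Cl)c(N)cc1OC)Cc1ccc(OC)cc1`: 0.2 mg/kg
- Compound 4 `COc1cc(N)c(Cl)cc1C(=O)NCCN(Cc1ccccc1)Cc1ccccc1`: not yet measured

For the measured compounds named here, compound 1 and compound 3 are the only two with numbers, and they lie within the scatter of each other: a 1.6-fold lower number from compound 1 to compound 3 (0.19 log units; within the scatter). Compound 4 puts phenyl in place of methyl on a saturated chain carbon bound to an amine nitrogen, which also reads as ethyl to benzyl: phenyl in place of methyl on a saturated chain carbon bound to an amine nitrogen.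

Going by the values given here, no measured step makes this same change. The nearest is an at least 96-fold higher number from compound 1 to compound 2 (1.98 log units; beyond the scatter), with hydrogen in place of benzyl on an amine nitrogen. That step is large and rests on a limit, but it removes a benzyl group rather than adding one. Methoxy in place of hydrogen on an aromatic carbon stayed within the scatter in a 1.6-fold lower number from compound 1 to compound 3 (0.19 log units; within the scatter). In this assay, no step beyond the scatter is therefore expected, with a slight lean towards a higher number. The expected step is a 1.6-fold higher number from compound 1 to compound 4 (0.21 log units; within the scatter). For compound 4 the estimated value is 0.5 mg/kg, with an expected range of 0.1 mg/kg to 3 mg/kg.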

Compound 4, dose for half-maximal effect: > 30 mg/kg
Compound 4: no number, only a limit (the forecaster's own chance of this, stated with the estimate: 10%); middle value at least 60-fold (1.77 log units) away from the limit.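

In this assay the ethyl group on the amine nitrogen turns out not to be interchangeable: with one benzyl kept on that nitrogen, ethyl to benzyl gives an at least 96-fold higher number from compound 1 to compound 4 (1.98 log units; beyond the scatter) and the low numbers are lost. Compound 4 gives > 30 mg/kg as a limit of the assay, not a number. For the compounds shown here, the earlier compounds showed only that the benzyl group tolerates a methoxy and that its removal loses the low number, whereas this result shows that a benzyl group on this nitrogen is not enough by itself and that the second substituent counts too.

Where between ethyl and benzyl the number starts to rise stays open, for instance with propyl or cyclohexylmethyl on this nitrogen. Compound 2 and compound 4 cannot be ordered against each other, because both end at the same limit: the limit of > 30 mg/kg in this assay, at which 2 of the 4 values shown sit.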